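Fluoro for Hydroxy on the Sulfone Aryl Ring

A few compounds are considered here, and "the series" means these few. Any claim that something is new, unique, unknown or untested is made for them only; others in the source may bear on it.

Compound 1 `CNCC1CCCc2cc(S(=O)(=O)c3ccccc3)ccc21`: 0.316 nM
Compound 2 `NC[C@@H]1CCCc2cc(S(=O)(=O)c3cccc(O)c3)ccc21`: 0.251 nM

In an assay on isolated protein for displacement of a labelled ligand from 5-hydroxytryptamine receptor 6 (Homo sapiens) (a lower number here means a stronger inhibitor, a higher number a weaker inhibitor), compound 2 gives 0.251 nM. Among the compounds with values here, compound 1 gives 0.316 nM in this assay; the two numbers sit within the usual scatter of each other, so neither compound can be said to bind more tightly than the other, and no single-point step between them is recorded.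

Compound 3 `NC[C@@H]1CCCc2cc(S(=O)(=O)c3cccc(F)c3)ccc21` has not been measured. It differs from compound 2 in one place: fluoro in place of hydroxy on an aromatic carbon. Compound 1, which has no hydroxy on that ring but also differs elsewhere, comes out within scatter of compound 2, so nothing seen so far points to a large effect from what sits on that ring. Compound 3 is therefore expected to stay close to compound 2, with the step of a 1.4-fold higher number from compound 2 to compound 3 (0.14 log units; within the scatter) expected to fall within the scatter. For compound 3 the estimate is 0.35 nM, within 0.12 nM to 1 nM.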

Compound 3, inhibition constant: 0.0794 nM
Compound 3: middle estimate off by 4.4-fold (0.64 log units), on the high side, and the stated range ends above it.
By their numbers in this assay, from the lowest: compound 3; then compounds 2 and 1 (each within the scatter of the next).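

In this assay, replacing hydroxy with fluoro on the aromatic carbon gives a 3.2-fold lower number from compound 2 to compound 3 (0.50 log units; beyond the scatter), so the group at this place does affect the number. Within the data shown here, this is the first step here between compounds that differ in one place, which ties the shift to this position alone: a 3-hydroxyphenyl becoming a 3-fluorophenyl, with the hydrogen-bond donor and acceptor counted for hydroxy gone and the number lower rather than higher, so hydroxy is not needed here for tight binding. Nothing measured on these compounds explains why the number falls.

Going by these compounds, with only hydroxy and fluoro compared at this position, it remains open whether fluoro itself matters or whether plain hydrogen, chloro, methoxy or a nitrile would do as well. On these data alone, it is also open whether the same swap would give a step of similar size with the methylamine side chain of compound 1.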